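Moving the chlorine: 2-chlorophenyl to 4-chlorophenyl

This account rests on a few compounds, and the source may have more. Where it says the series, first, only, none or still open, it means among the compounds named here.

- Compound 1 `C/C(=C\CC/C(C)=C/CC[C@@H]1[C@@]2(C)CCC(=O)C(C)(C)[C@H]2CC[C@@]1(C)O)CC/C=C(\C)C(=O)OCc1cn(-c2ccc([N+](=O)[O-])cc2)nn1` gives > 150000 nM as a limit
- Compound 2 `C/C(=C\CC/C(C)=C/CC[C@@H]1[C@@]2(C)CCC(=O)C(C)(C)[C@H]2CC[C@@]1(C)O)CC/C=C(\C)C(=O)OCc1cn(-c2ccccc2Cl)nn1` gives > 150000 nM as a limit

In an ADME assay on L132 cells (Homo sapiens) for cytotoxicity, read by MTT assay, with a stated time of 48 h (a lower number here means a stronger inhibitor, a higher number a weaker inhibitor), compound 2 stands at > 150000 nM which is a limit and not a number. Among the measured compounds shown here, the series so far shows the limit of > 150000 nM in this assay, at which 2 of the 2 values shown sit, and nothing finer. Compound 3 `C/C(=C\CC/C(C)=C/CC[C@@H]1[C@@]2(C)CCC(=O)C(C)(C)[C@H]2CC[C@@]1(C)O)CC/C=C(\C)C(=O)OCc1cn(-c2ccc(Cl)cc2)nn1` brings this change: 4-chlorophenyl in place of 2-chlorophenyl on an aromatic nitrogen with 4-chlorophenyl in place of 2-chlorophenyl on an aromatic nitrogen. For the measured compounds named here, the only measured step is a step that the two limits leave unreadable from compound 1 to compound 2 and it offers no size to carry over. No step beyond the scatter is expected in this assay in either direction, so the expected step is a step that the limit leaves unreadable from compound 2 to compound 3 and a further limit is likely. Compound 3 is expected at 200000 nM (estimated range 100000 nM to 400000 nM).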

Compound 3, half-maximal inhibitory concentration: > 150000 nM
Compound 3 ended at the assay's limit; the forecaster's own chance of this, stated with the estimate: 85%; the middle value does not contradict the limit.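

No step among compound 1, compound 2 and compound 3 can be read in this assay, as each value is a limit: the limit of > 150000 nM in this assay, at which 3 of the 3 values shown sit.

The compounds shown leave open which change, if any, would give a value inside the readable range of this assay.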